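The source may report more compounds than this note shows. Statements on the series, on what has been measured and on what is new or still open speak of the compounds shown alone.

In a functional assay on DU-145 cells (Homo sapiens) for inhibition, read by trypan blue exclusion, with a stated time of 96 h (on this read-out lower numbers stand for stronger inhibition of growth and higher numbers for weaker inhibition of growth), compound 1 `Cc1ccc(CS/C(=C/c2cc(C)ccc2C)C(=O)c2ccc(Cl)cc2)cc1` gives 10000 nM. Compound 2 `Cc1ccc(CS/C(=C/c2ccc(N(C)C)cc2)C(=O)c2ccc(Cl)cc2)cc1` gives > 100000 nM, which is a limit of the assay and not a number. The series thus has (the limit of > 100000 nM in this assay, at which 1 of the 2 values shown sits), and compound 2 has no measured position beyond it.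

For the measured compounds named here, the only measured step is an at least 10-fold higher number from compound 1 to compound 2 (1.00 log units; beyond the scatter), with 4-(dimethylamino)phenyl in place of 2,5-dimethylphenyl. Compound 3 `Cc1ccc(CS/C(=C/c2cccc(Cl)c2Cl)C(=O)c2ccc(Cl)cc2)cc1` carries the next change: 2,3-dichlorophenyl in place of 4-(dimethylamino)phenyl on a double-bonded chain carbon bound to a double-bonded chain carbon. It sits on a double-bonded chain carbon bound to a double-bonded chain carbon.

Compound 3 also lacks the 4-(dimethylamino)phenyl, so it is expected to fall back towards compound 1 at 10000 nM, although 2,3-dichlorophenyl is not 2,5-dimethylphenyl and this rests on a single step. In this assay the expected change is an at least 10-fold lower number from compound 2 to compound 3 (1.00 log units; beyond the scatter), towards a lower number. For compound 3 the estimate is 10000 nM, with an expected range of 2500 nM to 50000 nM.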

Compound 3, concentration for 50% growth inhibition: 25000 nM
Compound 3: the middle estimate sits 2.5-fold (0.40 log units) below what was measured; the range from low to high includes it.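

In this assay, 2,3-dichlorophenyl on a double-bonded chain carbon bound to a double-bonded chain carbon brings the series back to a measured value, with an at least 4.0-fold lower number from compound 2 to compound 3 (0.60 log units; beyond the scatter). That step is only a bound, since the value of compound 2 is a limit of the assay and not a number: the limit of > 100000 nM in this assay, at which 1 of the 3 values shown sits. Removing 4-(dimethylamino)phenyl does not by itself settle the level of growth inhibition, as the two groups that replace it also differ, with a 2.5-fold higher number from compound 1 to compound 3 (0.40 log units; beyond the scatter).

On these data alone, whether 4-aminophenyl or 4-carboxyphenyl would stay at the limit reached by compound 2 remains open. So does whether unsubstituted phenyl would sit nearer compound 1 or compound 3, and whether the order of these groups holds on other versions of the shared core.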